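Benzyl-Substituted Adenosine Analogues: Three Limits, One Prediction

The source may report more compounds than this note shows. Statements on the series, on what has been measured and on what is new or still open speak of the compounds shown alone.

Measured so far:
compound 1 `OC[C@H]1O[C@@H](n2cnc3c(NCc4ccccc4Br)ncnc32)[C@H](O)[C@@H]1O` — > 166000 nM
compound 2 `OC[C@H]1O[C@@H](n2cnc3c(NCc4ccc(Br)cc4)ncnc32)[C@H](O)[C@@H]1O` — > 166000 nM
compound 3 `OC[C@H]1O[C@@H](n2cnc3c(NCc4c(F)ccc(F)c4F)ncnc32)[C@H](O)[C@@H]1O` — > 166000 nM

All three share one core and differ only in the group on a saturated chain carbon bound to a nitrogen on an aromatic ring. In a functional assay on B16 cells (Mus musculus) for antiproliferative activity, with a stated time of 72 h (on this read-out lower numbers stand for stronger inhibition and higher numbers for weaker inhibition), compound 1 gives > 166000 nM, which is a limit of the assay and not a number. In this assay compound 2 gives > 166000 nM, likewise a limit. In this assay compound 3 gives > 166000 nM, again a limit. Compound 2 thus stands where every measured compound stands: at the limit of > 166000 nM in this assay, at which 3 of the 3 values shown sit. The steps a step that the two limits leave unreadable from compound 1 to compound 2, a step that the two limits leave unreadable from compound 1 to compound 3 and a step that the two limits leave unreadable from compound 2 to compound 3 are therefore all unreadable in size and direction.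

Compound 4 `OC[C@H]1O[C@@H](n2cnc3c(NCc4ccc(F)c(Cl)c4)ncnc32)[C@H](O)[C@@H]1O` differs from compound 2 by 3-chloro-4-fluorophenyl in place of 4-bromophenyl on a saturated chain carbon bound to a nitrogen on an aromatic ring. Every measured step that bears on this change is unreadable, so no direction beyond the scatter can be expected; the most likely outcome is another limit, and the expected step that the limit leaves unreadable from compound 2 to compound 4 is taken as flat. Compound 4 is estimated at 200000 nM, with a range from 100000 nM to 500000 nM.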

Compound 4, half-maximal inhibitory concentration: 167000 nM
For compound 4 the middle estimate is 1.2-fold (0.08 log units) above the measured one, and the stated range covers the measured number.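

Within the data shown here, compound 1, compound 2 and compound 3 each give only a limit, so no step from any of them to compound 4 can be read in size or direction. The compounds shown leave open which group at this place, if any, would give clearly stronger inhibition in this assay.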